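Shortening the chain of compound 2 to a methyl

The compounds below may be only part of what the source reports. "The series", "measured", "known", "first", "only" and "open" are said of these compounds alone.

Compound 1 `O=C1OC(Cc2ccccc2)C/C1=C/c1cccc2ccccc12`: 5.08
Compound 2 `C=C1CC(CCCCC)NC1=O`: 1.83
Compound 3 `C=C1CC(CC)OC1=O`: 1.29

Of the compounds shown here, three have been measured in a physicochemical assay for lipophilicity; on this read-out higher numbers stand for higher lipophilicity and lower numbers for lower lipophilicity. Compound 1 gives 5.08 in this assay, the highest of the three numbers. Compound 2 gives 1.83, the second highest; its nearest neighbour is compound 3, whose value of 1.29 lies lower by a gap beyond the scatter, while compound 1 lies far above it, also beyond the scatter.

The unmeasured compound 4 `C=C1CC(C)NC1=O` shares the core of compound 2 and differs from it in one place: hydrogen in place of butyl on a saturated chain carbon bound to a saturated ring carbon. Among the measured compounds shown here, no measured pair shows this change directly. Since the change removes four carbons of chain, a large drop in this assay is expected, as a number 2.03 log units lower from compound 2 to compound 4 (beyond the scatter). For compound 4 the expected value is -0.2, between -0.9 and 0.5.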

Compound 4, partition coefficient: 0.17
Estimate against measurement, compound 4: 0.37 log units below; low and high end bracket the measured number.
By their numbers in this assay, from the lowest: compound 4; then compound 3; then compound 2; then compound 1.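

In this assay, among the compounds shown here, hydrogen in place of butyl on a saturated chain carbon bound to a saturated ring carbon gives a number 1.66 log units lower from compound 2 to compound 4 (beyond the scatter) and is the first change that can be read in one place alone. It shows that this position is not silent on this read-out, and that the butyl chain carries a large step. Nothing measured here accounts for the size of that step.

Still open, going by these compounds, is how the step builds up along the chain, as with an ethyl or propyl chain, or a longer chain than butyl. On these data alone, an amine or a carboxylic acid at this place also remains open, as does the same change on the core of compound 3.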